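A few compounds are considered here, and "the series" means these few. Any claim that something is new, unique, unknown or untested is made for them only; others in the source may bear on it.

In a functional assay on PC-3 cells (Homo sapiens), read by MTT assay, with a stated time of 48 h (a lower number here means a stronger inhibitor, a higher number a weaker inhibitor), the measured compounds give these values
compound 1 `CCn1c(C(=O)NCCN(C)C)ccc1C(CC)(CC)c1ccc(OCC(=O)C(C)(C)C)c(C)c1` gives 2300 nM
compound 2 `CCN(CC)CCCNC(=O)c1ccc(C(CC)(CC)c2ccc(OCC(=O)C(C)(C)C)c(C)c2)n1CC` gives 1800 nM
compound 3 `CCn1c(C(=O)NCC(OC)OC)ccc1C(CC)(CC)c1ccc(OCC(O)C(C)(C)C)c(C)c1` gives 14600 nM

Compound 3 has the highest number of the three, which makes it the weakest inhibitor so far. Compound 4 `CCn1c(C(=O)N(C)CC(=O)O)ccc1C(CC)(CC)c1ccc(OCC(O)C(C)(C)C)c(C)c1` has (carboxymethyl)(methyl)amino in place of (2,2-dimethoxyethyl)amino on a carbonyl carbon. Going by the values given here, only one measured step changes this side chain (a 1.3-fold lower number from compound 1 to compound 2 (0.11 log units; within the scatter)). It lies within the scatter and involves no carboxymethyl group, so it offers only weak guidance. No step beyond the scatter is therefore expected in this assay, and no direction can be firmly predicted. The expected change is small (a 1.2-fold higher number from compound 3 to compound 4 (0.09 log units; within the scatter)). Compound 4 is estimated at 18000 nM (expected range 5000 nM to 60000 nM).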

Compound 4, half-maximal inhibitory concentration: 23900 nM
The estimate for compound 4 lay 1.3-fold (0.12 log units) below the measured number; low and high end bracket the measured number.
By their numbers in this assay, from the lowest: compounds 2 and 1 (each within the scatter of the next); then compounds 3 and 4 (each within the scatter of the next).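

In this assay, (carboxymethyl)(methyl)amino in place of (2,2-dimethoxyethyl)amino on a carbonyl carbon gives a 1.6-fold higher number from compound 3 to compound 4 (0.21 log units; within the scatter), a step that stays within the scatter. The earlier step at this carbonyl carbon joined two amine side chains, whereas this one shows that a side chain ending in a carboxylic acid leaves the number in the same range as the neutral dimethoxy chain. No measured evidence accounts for this result. Still open, as far as these compounds go, is how a longer chain ending in a carboxylic acid would read at this carbonyl carbon, or the same acid without the methyl group on its nitrogen.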